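From 4-nitrophenyl to 2-methylphenyl on an aromatic nitrogen

A few compounds are considered here, and "the series" means these few. Any claim that something is new, unique, unknown or untested is made for them only; others in the source may bear on it.

Compound 1 `CC(C)=CCC1=C(OCc2cn(-c3ccc(S(N)(=O)=O)cc3)nn2)C(=O)c2ccccc2C1=O`: 483000 nM
Compound 2 `CC(C)=CCC1=C(OCc2cn(-c3ccc([N+](=O)[O-])cc3)nn2)C(=O)c2ccccc2C1=O`: 540000 nM

In an ADME assay on HepG2 cells (Homo sapiens) for cytotoxicity, read by MTT assay, with a stated time of 24 h (on this read-out lower numbers stand for higher toxicity in this test and higher numbers for lower toxicity in this test), compound 2, at 540000 nM, stands level with compound 1, at 483000 nM. Compound 3 `CC(C)=CCC1=C(OCc2cn(-c3ccccc3C)nn2)C(=O)c2ccccc2C1=O` brings (2-methylphenyl in place of 4-nitrophenyl on an aromatic nitrogen), that is, 2-methylphenyl in place of 4-nitrophenyl on an aromatic nitrogen. Among the compounds with values here, the only measured step, a 1.1-fold higher number from compound 1 to compound 2 (0.05 log units; within the scatter), changed a group on this same aryl substituent, nitro in place of sulfamoyl on an aromatic carbon, and it stayed small. Within the data shown here, no measured compound carries 2-methylphenyl, so the evidence is thin, but no shift beyond the scatter is expected in this assay. The expected step is a 1.1-fold lower number from compound 2 to compound 3 (0.05 log units; within the scatter). For compound 3 the estimated value is 480000 nM, with an expected range of 230000 nM to 1000000 nM.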

Compound 3, half-maximal cytotoxic concentration: 256000 nM
Estimate against measurement, compound 3: 1.9-fold (0.27 log units) above; low and high end bracket the measured number.
By their numbers in this assay, from the lowest: compounds 3, 1 and 2 (each within the scatter of the next, the first and the last beyond it).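

In this assay, the group on the aromatic nitrogen can move the number beyond the scatter: 2-methylphenyl in place of 4-nitrophenyl gives a 2.1-fold lower number from compound 2 to compound 3 (0.32 log units; beyond the scatter), a modest step. In place of 4-sulfamoylphenyl, the same 2-methylphenyl gives a 1.9-fold lower number from compound 1 to compound 3 (0.28 log units; within the scatter), so the reading at this position depends on which group leaves. Nothing measured here accounts for this shift. The compounds shown leave open how an amine or a carboxylic acid on this phenyl ring, or a longer chain in place of the methyl, would read in this assay.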